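Ether side-chain variation in a hormone-receptor binding series

A few compounds are considered here, and "the series" means these few. Any claim that something is new, unique, unknown or untested is made for them only; others in the source may bear on it.

Measured so far:
- Compound 1, `CC(C)=CCOc1cccc2ccc(N)nc12`. In an assay on cells with melanin-concentrating hormone receptor 1 (Homo sapiens) as the target, read by radioligand binding (on this read-out lower numbers stand for stronger inhibition and higher numbers for weaker inhibition), compound 1 gives > 2000 nM, which is a limit of the assay and not a number.
- Compound 2, `CCC#CCOc1cccc2ccc(N)nc12`. In this assay compound 2 gives > 2000 nM, again a limit of the assay.
- Compound 3, `Nc1ccc2cccc(OC3CCCC3)c2n1`. In this assay compound 3 gives > 2000 nM, also a limit of the assay.

All three values sit at the same limit, as the limit of > 2000 nM in this assay, at which 3 of the 3 values shown sit, records. The three one-place exchanges among them are therefore a step that the two limits leave unreadable from compound 1 to compound 2, a step that the two limits leave unreadable from compound 1 to compound 3 and a step that the two limits leave unreadable from compound 2 to compound 3: none of them can be read as a step of any size, in either direction. Compound 3 thus stands nowhere in particular on the numbers shown; it is simply one of three limit values.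

The next compound, compound 4, `Nc1ccc2cccc(OCC3CC3)c2n1`, keeps everything of compound 3 except the ether substituent: cyclopropylmethyl in place of cyclopentyl on an oxygen on an aromatic ring. The measured exchanges that bear on this change are the two that alter the same oxygen-bound group, and both are unreadable, so no size or direction of step can be inferred from them. With all neighbours at the limit, the expectation is that the new cyclopropylmethyl ether behaves much like the cyclopentyl ether.

Compound 4 is therefore expected to give 3000 nM in this assay, with a range from 1200 nM to 10000 nM. The step this estimate implies is expected to be a step that the limit leaves unreadable from compound 3 to compound 4, most probably another limit rather than a readable number.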

Compound 4, half-maximal inhibitory concentration: > 2000 nM
Compound 4 ended at the assay's limit; the forecaster's own chance of this, stated with the estimate: 75%; the middle value is on the limit's open side.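

In this assay compound 4 gives > 2000 nM as a limit of the assay and not a number. Its exchanges with compound 1, compound 2 and compound 3 cannot be read as steps of any size, as all four values coincide: the limit of > 2000 nM in this assay, at which 4 of the 4 values shown sit. The compounds shown leave open how strongly any of these ether side chains inhibits, and whether any differs from the others.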